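Amide substituent changes and permeability across a shared core

This account rests on a few compounds, and the source may have more. Where it says the series, first, only, none or still open, it means among the compounds named here.

Compound 3 `CNC(=O)c1cc(C(=O)NC(C)CO)n([C@@H](C)c2ccccc2)n1` gives 120 nm/s in an ADME assay for permeability; on this read-out lower numbers stand for lower permeability and higher numbers for higher permeability. Among the three measured compounds it holds the second highest number: compound 2 `CNC(=O)c1cc(C(=O)N[C@H]2CC[C@H](O)CC2)n([C@@H](C)c2ccccc2)n1`, at 80 nm/s, lies nearest and within the scatter of it, while compound 1 `CNC(=O)c1cc(C(=O)NC2CCOCC2)n([C@@H](C)c2ccccc2)n1`, at 270 nm/s, lies furthest and beyond the scatter, so only compound 1 stands clearly apart from compound 3.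

Compound 4 `CNC(=O)c1cc(C(=O)N[C@H]2[C@@H]3C[C@@H](OC)C[C@@H]32)n([C@@H](C)c2ccccc2)n1` is not yet measured in this assay. It differs from compound 3 in one place: a group of 8 heavy atoms (7 carbon, 1 oxygen; one three-membered non-aromatic ring of carbon only, one five-membered non-aromatic ring of carbon only) in place of a group of 4 heavy atoms (3 carbon, 1 oxygen; no ring), on an amide-type nitrogen. The group that leaves carries one hydrogen-bond donor; the group that enters carries none and keeps one hydrogen-bond acceptor, as the oxan-4-yl of compound 1 does.

Among the measured compounds shown here, two measured steps bear on this. a 2.3-fold lower number from compound 1 to compound 3 (0.35 log units; beyond the scatter) and a 3.4-fold lower number from compound 1 to compound 2 (0.53 log units; beyond the scatter) both run from an acceptor-only group to a donor-bearing one and both lower the number beyond the scatter. The change to compound 4 runs the other way, so a rise beyond the scatter is expected in this assay, of about the size seen between compound 1 and compound 3. For compound 4 the expected step is a 2.7-fold higher number from compound 3 to compound 4 (0.43 log units; beyond the scatter). Compound 4 is therefore estimated at 320 nm/s, with a range from 150 nm/s to 700 nm/s.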

Compound 4, apparent permeability: 440 nm/s
Beside the measured number, compound 4's estimate is 1.4-fold (0.14 log units) below it; measured number inside the range.
By their numbers in this assay, from the lowest: compounds 2 and 3 (each within the scatter of the next); then compounds 1 and 4 (each within the scatter of the next).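

On the amide-type nitrogen, the group with a three-membered and a five-membered carbon ring and 0 hydrogen-bond donors gives a 3.7-fold higher number from compound 3 to compound 4 (0.56 log units; beyond the scatter) and a 5.5-fold higher number from compound 2 to compound 4 (0.74 log units; beyond the scatter), so it stands clearly apart from both donor-bearing groups, as the oxan-4-yl of compound 1 does. Between the two donor-free groups the step is a 1.6-fold higher number from compound 1 to compound 4 (0.21 log units; within the scatter), so in this assay these different ring groups are not separated, and among these four compounds none goes against the split between donor-free and donor-bearing groups. No measurement shown accounts for this split.

A hydroxyl in place of the methoxy on the same ring pair would test the split on a fixed ring group. An open methoxyalkyl chain, or an amine, on this nitrogen also remains to be placed against these four numbers.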